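A few compounds are considered here, and "the series" means these few. Any claim that something is new, unique, unknown or untested is made for them only; others in the source may bear on it.

Measured so far in a functional assay on L6 cells (Rattus norvegicus) for inhibition, read by scintillation counting, with a stated time of 3 h; a higher number here means a weaker inhibitor, a lower number a stronger inhibitor:
- compound 1 `Cc1ccccc1CNC(=O)c1nc(-c2ccc(F)cc2)n(CC[C@@H](O)C[C@@H](O)CC(=O)O)c1C1CC1`: 4850 nM
- compound 2 `O=C(O)C[C@H](O)C[C@H](O)CCn1c(-c2ccc(F)cc2)nc(C(=O)NCc2ccc(F)c(F)c2)c1C1CC1`: 2780 nM
- compound 3 `O=C(O)C[C@H](O)C[C@H](O)CCn1c(-c2ccc(F)cc2)nc(C(=O)NCc2ccc(F)cc2)c1C1CC1`: 1620 nM

Compound 3 stands clearly apart from only one of the other two compounds. The data show a 3.0-fold lower number from compound 1 to compound 3 (0.48 log units; beyond the scatter), while they also show a 1.7-fold lower number from compound 2 to compound 3 (0.23 log units; within the scatter). Compound 3 and compound 2 therefore cannot be ranked against each other.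

The next compound is compound 4 `COc1cccc(CNC(=O)c2nc(-c3ccc(F)cc3)n(CC[C@@H](O)C[C@@H](O)CC(=O)O)c2C2CC2)c1`. It keeps the shared core and exchanges 4-fluorobenzyl for 3-methoxybenzyl: 3-methoxyphenyl in place of 4-fluorophenyl on a saturated chain carbon bound to an amide-type nitrogen. The change sits on a saturated chain carbon bound to an amide-type nitrogen, the same place that varies across the measured compounds.

For the measured compounds named here, those compounds supply the only guidance, and none of them carries a methoxy group. Besides the two steps above, the third step at this place is a 1.7-fold lower number from compound 1 to compound 2 (0.24 log units; within the scatter). Going by the values given here, all three are small, and only the step to compound 3 from compound 1 passes the scatter. Leaving 4-fluorophenyl is therefore expected to give a somewhat higher number in this assay, though the move may well stay within the scatter. The expected change is a 1.7-fold higher number from compound 3 to compound 4 (0.24 log units; within the scatter). For compound 4 the estimated value is 2800 nM, with an expected range of 1200 nM to 6500 nM.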

Compound 4, half-maximal inhibitory concentration: 538 nM
The estimate for compound 4 lay 5.2-fold (0.72 log units) above the measured number; the measured number lies below the stated range.
By their numbers in this assay, from the lowest: compound 4; then compounds 3, 2 and 1 (each within the scatter of the next, the first and the last beyond it).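

In this assay, the place on a saturated chain carbon bound to an amide-type nitrogen proved to have more range than the first three compounds suggested: 3-methoxyphenyl gives a 3.0-fold lower number from compound 3 to compound 4 (0.48 log units; beyond the scatter) and a 5.2-fold lower number from compound 2 to compound 4 (0.71 log units; beyond the scatter) and also a 9.0-fold lower number from compound 1 to compound 4 (0.95 log units; beyond the scatter) in steps that all lie beyond the scatter, which makes compound 4 the strongest inhibitor of the four. Among the earlier compounds, the only step at this place to pass the scatter was the one from compound 1 to compound 3, whereas compound 4 now stands clearly apart from all the others. Compound 4 is also the only one of the four whose group here has an oxygen atom and a hydrogen-bond acceptor, but this single compound sets no pattern, and nothing available explains its lower number.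

Compound 4 differs from the others in both the group it carries and where that group sits, so the compounds shown cannot separate the contribution of the methoxy group from that of its placement. They also leave open whether a hydroxyl group, an ethoxy group or an amine on the same ring would match the methoxy group.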